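The compounds below may be only part of what the source reports. "The series", "measured", "known", "first", "only" and "open" are said of these compounds alone.

Compound 2 `COc1ccc(Oc2ccccc2-c2ccsc2S(=O)(=O)N2CCN(C(=S)Nc3ccc(Cl)cc3)CC2)cc1OC` and compound 1 `COc1ccc(Oc2ccc([N+](=O)[O-])cc2-c2ccsc2S(=O)(=O)N2CCN(C(=S)Nc3ccc(Cl)cc3)CC2)cc1OC` share one core and differ in a single change, (nitro in place of hydrogen on an aromatic carbon). In an assay for binding affinity to Apoptosis regulator Bcl-2 (Homo sapiens), read by fluorescence polarization, with stated times of 30 min and 20 min, tested at 100 uM (on this read-out lower numbers stand for less inhibition and higher numbers for more inhibition at the one concentration tested (going by the name of the read-out)), compound 2 gives 18%, and compound 1 gives 18%, so the step is no change at the digits printed from compound 2 to compound 1 (within the scatter). Compound 3 `O=S(=O)(c1sccc1-c1ccccc1Oc1ccc(O)c(O)c1)N1CCN(C(=S)Nc2cc(C(F)(F)F)cc(C(F)(F)F)c2)CC1` rests on a second core; the difference between the two cores is not broken down here. In this assay compound 3 gives 20%, a number within the scatter of the other two. Compound 4 `O=[N+]([O-])c1ccc(Oc2ccc(O)c(O)c2)c(-c2ccsc2S(=O)(=O)N2CCN(C(=S)Nc3cc(C(F)(F)F)cc(C(F)(F)F)c3)CC2)c1` arises from compound 3 through (nitro in place of hydrogen on an aromatic carbon), the same kind of change as from compound 2 to compound 1, though here the place is para to a 3,4-dihydroxyphenoxy group rather than a 3,4-dimethoxyphenoxy group. Because no change at the digits printed from compound 2 to compound 1 (within the scatter) shows that change left the number unmoved, the expected step is no change at the digits printed from compound 3 to compound 4 (within the scatter). Compound 4 is therefore estimated at 20% in this assay, most likely between 10% and 30%.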

Compound 4, a percentage reported as inhibition, at one concentration (the size of the read-out at that concentration, not a potency): 12%
Compound 4: middle estimate off by 8 percentage points, on the high side; the range from low to high includes it.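

In this assay, putting nitro in place of hydrogen on an aromatic carbon gives a number 8 percentage points lower from compound 3 to compound 4 (within the scatter). Set beside the earlier step, the same change shows no detectable difference between the two cores: the same change on two cores in this assay, no change at the digits printed (within the scatter) from compound 2 to compound 1 and a number 8 percentage points lower (within the scatter) from compound 3 to compound 4, 8 percentage points apart, within the scatter of two such steps. Among these compounds, this suggests that the change transfers between these two cores without a clear effect, but it rests on only two pairs read at one concentration, so it gives no potency and cannot show how the change would behave on a core with a much higher number.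

Going by these compounds, it remains open what an amine or a carboxylic acid would do in the same place. Also open, on these data alone, is how the 3,4-dihydroxyphenoxy and 3,4-dimethoxyphenoxy groups compare when everything else in the molecule is the same.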